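The compounds below may be only part of what the source reports. "The series", "measured", "known", "first", "only" and "open" are said of these compounds alone.

In a functional assay on HT-29 cells (Homo sapiens) for antiproliferative activity, read by MTT assay, with a stated time of 48 h (on this read-out lower numbers stand for stronger inhibition of growth and higher numbers for weaker inhibition of growth), compound 1 (`CCOC(=O)N1N=C(c2ccccc2)CC1c1cc(OC)c(OC)c(OC)c1`) gives 8920 nM and compound 2 (`COC(=O)N1N=C(c2ccc(OC)cc2)CC1c1cc(OC)c(OC)c(OC)c1`) gives 2550 nM as the lower of the two numbers, a gap beyond the usual scatter. These two compounds differ in more than one place, so the gap cannot be assigned to any single change.

Compound 3 (`CCOC(=O)N1N=C(c2ccc(OC)cc2)CC1c1cc(OC)c(OC)c(OC)c1`) differs from compound 2 in one place: methyl in place of hydrogen on a saturated chain carbon bound to an oxygen next to a carbonyl group on a saturated chain carbon bound to an oxygen next to a carbonyl group, so methoxycarbonyl becomes ethoxycarbonyl.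

For the measured compounds named here, no measured pair isolates this change, which leaves only weak grounds for an expectation. Compound 1, which also carries ethoxycarbonyl, stands at 8920 nM but differs from compound 3 elsewhere as well, so it suggests a direction and little about size. A small shift toward a higher number in this assay is therefore expected, probably not beyond the scatter. The estimated step of a 1.4-fold higher number from compound 2 to compound 3 (0.14 log units; within the scatter) is correspondingly modest. For compound 3 the expected value is 3500 nM with an estimated range from 1300 nM to 9000 nM as the working figure.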

Compound 3, concentration for 50% growth inhibition: 6730 nM
Beside the measured number, compound 3's estimate is 1.9-fold (0.28 log units) below it; measured number inside the range.
By their numbers in this assay, from the lowest: compound 2; then compounds 3 and 1 (each within the scatter of the next).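

In this assay, methyl in place of hydrogen on a saturated chain carbon bound to an oxygen next to a carbonyl group gives a 2.6-fold higher number from compound 2 to compound 3 (0.42 log units; beyond the scatter), so this position responds to the change from methoxycarbonyl to ethoxycarbonyl, a result that the two earlier compounds, which differ in more than one place, could not isolate. The other single change, methoxy in place of hydrogen on an aromatic carbon, gives a 1.3-fold lower number from compound 1 to compound 3 (0.12 log units; within the scatter), which is within the scatter, so with ethoxycarbonyl present this methoxy group makes no readable difference, and among these three compounds only the methoxycarbonyl to ethoxycarbonyl step is readable. Nothing on hand accounts for the size of the step at the carbonyl side chain.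

From the compounds shown here alone, it remains open whether the trend continues with a longer chain such as propoxycarbonyl, or how a carboxylic acid or an amide would read at the same place. For the compounds shown here, also open is whether the aromatic methoxy group stays without a readable effect alongside methoxycarbonyl, since the only pair isolating that change carries ethoxycarbonyl.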